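Swapping the bicyclic amide head in a sulfone series

A few compounds are considered here, and "the series" means these few. Any claim that something is new, unique, unknown or untested is made for them only; others in the source may bear on it.

In an assay for inhibition of Nicotinamide phosphoribosyltransferase (Homo sapiens), read by mass spectrometry, with stated times of 15 min and 30 min (on this read-out higher numbers stand for weaker inhibition and lower numbers for stronger inhibition), compound 2 `O=C(NCc1ccc(S(=O)(=O)c2ccccc2)cc1)c1cc2ccncc2s1` gives 7 nM, the lowest of the two numbers in hand, while compound 1 `Cc1cccc(S(=O)(=O)c2ccc(CNC(=O)c3cc4cnccc4[nH]3)cc2)c1` gives 8 nM, a gap within the scatter. Compound 3 `O=C(NCc1ccc(S(=O)(=O)c2ccccc2)cc1)c1cnc2nccn2c1` is not yet measured. Relative to compound 2 it carries a group of 9 heavy atoms (6 carbon, 3 nitrogen; one five-membered aromatic ring with 2 hetero atoms, one six-membered aromatic ring with 2 hetero atoms) in place of a group of 9 heavy atoms (7 carbon, 1 nitrogen, 1 sulfur; one five-membered aromatic ring with 1 hetero atom, one six-membered aromatic ring with 1 hetero atom), on a carbonyl carbon. Among the measured compounds shown here, no step between measured compounds is available for a change of this kind, so the size of the step is uncertain; a modest loss in this assay is expected, with the step from a 4.3-fold higher number from compound 2 to compound 3 (0.63 log units; beyond the scatter). On that basis compound 3 is expected to give 30 nM, in a range of 7 nM to 150 nM.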

Compound 3, half-maximal inhibitory concentration: 2 nM
Compound 3: middle estimate off by 15-fold (1.18 log units), on the high side, outside the stated range (below it).
By their numbers in this assay, from the lowest: compound 3; then compounds 2 and 1 (each within the scatter of the next).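

In this assay the group of 6 carbon and 3 nitrogen atoms on the carbonyl carbon is more than tolerated, giving a 3.5-fold lower number from compound 2 to compound 3 (0.54 log units; beyond the scatter), a modest step. Among the compounds shown here, compounds 1 and 2 differ in more than one place, so this is the first reading of this position alone, and it shows that a low number here does not need the sulfur of compound 2. Nothing available accounts for the step. Going by these compounds, whether a single pyridine ring on this carbonyl carbon would keep such a number remains open. So does whether the step carries over to the methyl-bearing sulfone of compound 1.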